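Shifting the Chlorine Around the Benzyl Ring

The source may report more compounds than this note shows. Statements on the series, on what has been measured and on what is new or still open speak of the compounds shown alone.

Of the compounds shown here, three sharing one core have been measured in an assay on CHO cells for displacement of a labelled ligand from adenosine receptor A3 (Homo sapiens), read by scintillation counting, tested at 1 uM; a higher number here means more inhibition at the concentration tested (going by the name of the read-out), a lower number less inhibition. Compound 1 `Cc1cccc(Cc2nc(N)c3nn(-c4ccccc4)cc3n2)c1` gives 11%, compound 2 `Cc1ccc(Cc2nc(N)c3nn(-c4ccccc4)cc3n2)cc1` gives 39%, and compound 3 `Nc1nc(Cc2ccccc2Cl)nc2cn(-c3ccccc3)nc12` gives 22%. Compound 3 therefore stands second highest of the three: compound 1 sits a number 11 percentage points higher from compound 1 to compound 3 (beyond the scatter) below it, while compound 2 sits above it by a number 17 percentage points lower from compound 2 to compound 3 (beyond the scatter). All three differ only in the aryl group attached to the saturated chain carbon bound to an aromatic carbon of the shared core.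

Compound 4 `Nc1nc(Cc2ccc(Cl)cc2)nc2cn(-c3ccccc3)nc12` is the next step from compound 3. The change is 4-chlorophenyl in place of 2-chlorophenyl on a saturated chain carbon bound to an aromatic carbon. Among the compounds with values here, the one measured step that bears on it is the move of the methyl group from the 3-position to the 4-position of the same ring, a number 28 percentage points higher from compound 1 to compound 2 (beyond the scatter), which helped by a modest but clear amount. Within the data shown here, the step from compound 3 to compound 4 moves the chlorine from the 2-position to the 4-position; no measured pair shows exactly this, so the expectation rests on the one analogous move. A modest increase in this assay is expected for compound 4, of about a number 16 percentage points higher from compound 3 to compound 4 (beyond the scatter), bringing it near compound 2. Compound 4 is thus estimated at 38%, with a likely range from 20% to 56%.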

Compound 4, a percentage reported as inhibition, at one concentration (the size of the read-out at that concentration, not a potency): 11%
Estimate against measurement, compound 4: 27 percentage points above; the whole stated range lies above it.
By their numbers in this assay, from the lowest: compounds 1 and 4 (each within the scatter of the next); then compound 3; then compound 2.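

In this assay, 4-chlorophenyl in place of 2-chlorophenyl on a saturated chain carbon bound to an aromatic carbon gives a number 11 percentage points lower from compound 3 to compound 4 (beyond the scatter), so moving the chlorine to this ring place does not repeat the gain seen when 4-methylphenyl replaced 3-methylphenyl. Chloro in place of methyl on an aromatic carbon, with the ring place unchanged, gives a number 28 percentage points lower from compound 2 to compound 4 (beyond the scatter), which shows that the result at this ring place depends on the group sitting there and that chloro and methyl cannot be treated as interchangeable in this series. Comparing 4-chlorophenyl with 3-methylphenyl gives no change at the digits printed from compound 1 to compound 4 (within the scatter), so these two different rings cannot be told apart in this assay.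

The compounds shown leave open how 3-chlorophenyl, 2-methylphenyl, or a phenyl ring carrying a methoxy group or an amine would read at this carbon, and so whether any consistent rule links the group and its ring place. Nothing available explains why the chlorine and methyl series part ways.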